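Hydroxamic acid series: aryl substituent change from compound 2

The source may hold more compounds than are shown below. What is called first, only, known or untested is meant among the compounds shown, and "the series" means these compounds.

Measured so far:
compound 1 `O=C(CCC1=CCN(CCCc2ccc(Cl)cc2)C1=O)NO` – 2210 nM
compound 2 `CCOc1ccc(CCCN2CC=C(CCC(=O)NO)C2=O)cc1` – 2210 nM
compound 3 `O=C(CCC1=CCN(Cc2cc(C(F)(F)F)cc(C(F)(F)F)c2)C1=O)NO` – 1990 nM

All three values come from a functional assay on MDA-MB-231 cells (Homo sapiens) for inhibition, read by sulforhodamine B assay; on this read-out lower numbers stand for stronger inhibition of growth and higher numbers for weaker inhibition of growth. Compound 2 stands level with compound 1 at the digits shown, the two together the highest of the three numbers; compound 3 sits within the scatter of both. Compound 4 `CC(C)c1ccc(CCCN2CC=C(CCC(=O)NO)C2=O)cc1` is not yet measured. Change: isopropyl in place of ethoxy on an aromatic carbon. Among the compounds with values here, the only comparable step, no change at the digits printed from compound 1 to compound 2 (within the scatter), exchanged one group for another on an aromatic carbon with no shift beyond the scatter. Nothing in the set separates groups at this position, so the step in this assay is expected to be a 1.1-fold lower number from compound 2 to compound 4 (0.02 log units; within the scatter), that is none beyond the scatter. Compound 4 is therefore estimated at 2100 nM, with a range of 1000 nM to 4500 nM.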

Compound 4, concentration for 50% growth inhibition: 2210 nM
Beside the measured number, compound 4's estimate is 1.1-fold (0.02 log units) below it; low and high end bracket the measured number.
By their numbers in this assay, from the lowest: compounds 3, 1, 2 and 4 (each within the scatter of the next).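

In this assay, the step of no change at the digits printed from compound 2 to compound 4 (within the scatter) swaps ethoxy, with one hydrogen-bond acceptor, for isopropyl, with none, and this count makes no visible difference at this place, para to a large group. With the step of no change at the digits printed from compound 1 to compound 4 (within the scatter) as well, chloro, ethoxy and isopropyl all stand level, now including a substituent of carbon only. Nothing measured here accounts for this flat response. Still open, on these data alone, is whether an amine or a carboxylic acid at this place would move the number, and whether a hydrogen-bond donor here would do so.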